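This account rests on a few compounds, and the source may have more. Where it says the series, first, only, none or still open, it means among the compounds named here.

Compound 1, `COc1ccc([C@]2(CO)NC[C@@H](O)[C@@H]2O)cc1`: 40.2%
Compound 2, `OC[C@@]1(c2c(F)c(F)c(F)c(F)c2F)NC[C@@H](O)[C@@H]1O`: 18.5%
Compound 3, `COc1ccc([C@@]2(CO)NC[C@H](O)[C@H]2O)cc1OC`: 27.1%

All three compounds share the core of compound 1 and were tested in an assay on isolated protein for inhibition of lysosomal alpha-glucosidase (Homo sapiens), tested at 1000 uM; a higher number here means more inhibition at the concentration tested (going by the name of the read-out), a lower number less inhibition. Compound 1 stands highest of the three numbers. The nearest of the others is compound 3, whose inhibition lies lower by a margin beyond the scatter, and the furthest is compound 2, lower still and also beyond the scatter. No pair among these three differs in one place only, so the measured values show only where each compound sits, not the effect of a single change.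

Compound 4, `Cc1ccc([C@]2(CO)NC[C@@H](O)[C@@H]2O)cc1`, has not yet been measured in this assay. It differs from compound 1 in one place: methyl in place of methoxy on an aromatic carbon. The methoxy leaves and a methyl enters on an aromatic carbon of a six-membered aromatic ring of carbon only.

Within the data shown here, no measured pair here shows what such a change does, so the expectation rests on compound 1 alone. Compound 4 is expected to stay close to compound 1, with the estimated step of a number 5.2 percentage points lower from compound 1 to compound 4 (within the scatter) lying within the usual scatter, perhaps a little lower. For compound 4 the estimated inhibition is 35%, with a range from 18% to 52%.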

Compound 4, a percentage reported as inhibition, at one concentration (the size of the read-out at that concentration, not a potency): 21.3%
For compound 4 the middle estimate is 13.7 percentage points above the measured one; the measured number falls inside the stated range.
By their numbers in this assay, from the lowest: compounds 2, 4 and 3 (each within the scatter of the next); then compound 1.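

Methyl in place of methoxy on an aromatic carbon, para to a group of 9 heavy atoms, gives a number 18.9 percentage points lower from compound 1 to compound 4 (beyond the scatter) in this assay and is the first single change on the shared core that can be read. It shows that this position is not indifferent to the group it carries: the swap takes away only one heavy atom and one hydrogen-bond acceptor, yet the step lies beyond the scatter. Nothing measured here tells why the read-out moves with this change.

What the compounds shown leave open is whether the oxygen of the methoxy or the group as a whole accounts for the step, since a hydroxyl, an ethyl or a chlorine on the same carbon would be needed to tell these readings apart. As far as these compounds go, it also remains open what either group contributes relative to a plain hydrogen at this place, and whether a longer chain such as ethoxy would carry the read-out further in the same direction or turn it back.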